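A few compounds are considered here, and "the series" means these few. Any claim that something is new, unique, unknown or untested is made for them only; others in the source may bear on it.

Values in a functional assay on MCF7 cells (Homo sapiens) for cytotoxicity, read by ELISA, with a stated time of 4 days; a higher number here means a weaker inhibitor, a lower number a stronger inhibitor:
- Compound 1 `Clc1ccc(-c2cc(-c3ccoc3)cc(-c3ccco3)n2)s1`: 4740 nM
- Compound 2 `Clc1ccc(-c2cc(-c3ccoc3)cc(-c3ccc(Cl)s3)n2)cc1`: 2600 nM

Compound 2 and compound 1 lie within the scatter of each other, so the two values give no order. In compound 3 `Clc1ccc(-c2cc(-c3ccoc3)cc(-c3ccccn3)n2)s1`, pyridin-2-yl replaces 4-chlorophenyl: pyridin-2-yl in place of 4-chlorophenyl on an aromatic carbon. For the measured compounds named here, only one measured step bears on this change, at the same aromatic carbon: a 1.8-fold lower number from compound 1 to compound 2 (0.26 log units; within the scatter). With furan-2-yl and 4-chlorophenyl giving values this close, no shift beyond the scatter is expected in this assay. The expected step, a 1.3-fold higher number from compound 2 to compound 3 (0.13 log units; within the scatter), is small and has no firm direction. For compound 3 the estimated value is 3500 nM, with an expected range of 1400 nM to 9000 nM.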

Compound 3, half-maximal inhibitory concentration: 3360 nM
Estimate against measurement, compound 3: 1.0-fold (0.02 log units) above; the measured number falls inside the stated range.
By their numbers in this assay, from the lowest: compounds 2, 3 and 1 (each within the scatter of the next).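

In this assay, pyridin-2-yl brings a ring nitrogen and a hydrogen-bond acceptor to this aromatic carbon, yet the readings are a 1.3-fold higher number from compound 2 to compound 3 (0.11 log units; within the scatter) and a 1.4-fold lower number from compound 1 to compound 3 (0.15 log units; within the scatter) in the series. With furan-2-yl, 4-chlorophenyl and pyridin-2-yl all within the scatter of one another, this position shows no order among these three groups. No measured evidence on the compounds bears on this result.

Open, on these data alone, is whether an amine, a carboxylic acid or a longer chain at this carbon would move the value beyond the scatter. Also open, as far as these compounds go, is what replacing the furan-3-yl group would do.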